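This account rests on a few compounds, and the source may have more. Where it says the series, first, only, none or still open, it means among the compounds named here.

Measured compounds:
compound 1 `CCN(CC)C(=O)c1ccc(S(=O)(=O)N2CCC[C@@H](C(=O)N3CCC(F)(F)CC3)C2)cc1` — 240 nM
compound 2 `CCN(CC)S(=O)(=O)c1ccc(S(=O)(=O)N2CCC[C@@H](C(=O)N3CCOCC3)C2)cc1` — 790 nM
compound 3 `CC(C)NS(=O)(=O)c1ccc(S(=O)(=O)N2CCC[C@@H](C(=O)N3CCC(F)(F)CC3)C2)cc1` — 470 nM

These three compounds were tested in a functional assay on BXPC-3 cells (Homo sapiens) for inhibition, read by MTT assay, with a stated time of 7 days; on this read-out higher numbers stand for weaker inhibition and lower numbers for stronger inhibition. Compound 2 gives the highest number of the three; its gap to compound 3 is within the scatter, while its gap to compound 1 lies beyond it, so compound 2 is among the weaker inhibitors here but cannot be set apart from compound 3.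

Compound 4 `CCN(CC)S(=O)(=O)c1ccc(S(=O)(=O)N2CCC[C@@H](C(=O)N[C@H]3CCOC3)C2)cc1` is not yet measured. It differs from compound 2 in one place: (oxolan-3-yl)amino in place of morpholin-4-yl on a carbonyl carbon. Within the data shown here, the only measured single-point step, a 2.0-fold higher number from compound 1 to compound 3 (0.29 log units; within the scatter), concerns a different position, the group on the aromatic carbon, and is itself within the scatter. Among the measured compounds shown here, no measured pair shows what exchanging the group on the carbonyl carbon does, so there is nothing to argue for a shift in either direction. Compound 4 is therefore expected to stay near the value of its parent, with a step of a 1.2-fold higher number from compound 2 to compound 4 (0.08 log units; within the scatter) expected. The estimate for compound 4 in this assay is 950 nM, with a range from 300 nM to 3200 nM.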

Compound 4, half-maximal inhibitory concentration: 5270 nM
Compound 4: middle estimate off by 5.5-fold (0.74 log units), on the low side, and the stated range ends below it.
By their numbers in this assay, from the lowest: compounds 1, 3 and 2 (each within the scatter of the next, the first and the last beyond it); then compound 4.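

In this assay the group on the carbonyl carbon proves to matter: (oxolan-3-yl)amino in place of morpholin-4-yl gives a 6.7-fold higher number from compound 2 to compound 4 (0.82 log units; beyond the scatter) and is the first change at this position among these compounds. The two groups hold the same atoms, yet a six-membered ring with 2 hetero atoms gives way to a five-membered ring with 1 hetero atom, and the amide hydrogen appears as a new hydrogen-bond donor. No measurement here explains the weaker inhibition, so the data cannot say which of these differences counts.

Going by these compounds, it remains open whether the ring or the amide hydrogen drives the step. A methyl(oxolan-3-yl)amino group, which keeps the five-membered ring but has no amide hydrogen, would separate the two, and the opposite stereoisomer of the oxolan-3-yl group is also untested here.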